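A few compounds are considered here, and "the series" means these few. Any claim that something is new, unique, unknown or untested is made for them only; others in the source may bear on it.

Measured compounds:
compound 1 `Nc1ccccc1NC(=O)c1ccc(CSC(=S)N2CCN(c3ccc(Cl)cc3)CC2)cc1` — 32.2%
compound 2 `CC1CCN(C(=S)SCc2ccc(C(=O)Nc3ccccc3N)cc2)CC1` — 32.7%
compound 3 `Nc1ccccc1NC(=O)c1ccc(CSC(=S)N2CCN(C(c3ccccc3)c3ccccc3)CC2)cc1` — 8.7%

In a functional assay on A-375 cells (Homo sapiens) for antiproliferative activity, read by CCK-8 assay, with a stated time of 72 h, tested at 2 uM (a higher number here means a stronger effect of the compound at the concentration tested, a lower number a weaker effect), compound 1 gives 32.2%, and compound 2 gives 32.7%; the two numbers lie within the scatter of each other, so nothing separates them. Compound 3, which in this assay gives 8.7%, stands well below both, the gap to compound 1 lying beyond the scatter. Going by the values given here, no two of the three measured compounds differ in only one place, so no single structural step between them can be read off.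

Compound 4 `Nc1ccccc1NC(=O)c1ccc(CSC(=S)N2CCN(c3ccc(F)cc3)CC2)cc1` has not yet been measured. It differs from compound 1 in one place: fluoro in place of chloro on an aromatic carbon. Among the compounds with values here, nothing among the measured compounds shows what this particular exchange does here. The change is small in size and leaves every other part of compound 1 untouched, so no step beyond the scatter is expected in either direction; the expected step from compound 1 to compound 4 is a number 3.2 percentage points lower from compound 1 to compound 4 (within the scatter). Compound 4 is therefore estimated to give 29% in this assay, within a range from 16% to 42%.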

Compound 4, a percentage reported as inhibition, at one concentration (the size of the read-out at that concentration, not a potency): 20.9%
Estimate against measurement, compound 4: 8.1 percentage points above; measured number inside the range.
By their numbers in this assay, from the lowest: compound 3; then compound 4; then compounds 1 and 2 (each within the scatter of the next).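

In this assay, going by these compounds alone, the exchange of 4-chlorophenyl for 4-fluorophenyl gives the first single change that can be read in this set: a number 11.3 percentage points lower from compound 1 to compound 4 (beyond the scatter), a modest step. This shows that the halogen on this aromatic carbon, para to a large group, is not interchangeable here, since replacing one heavy atom with another, with no change in the counted hydrogen-bond donors, acceptors or net charge, is enough to move the read-out. Nothing given on these compounds accounts for the step.

The compounds shown leave open how bromo, methoxy or plain hydrogen at this place would compare with chloro and fluoro, so no trend across such groups can be drawn from one pair. They also leave open whether the same exchange would give a similar step on the other compounds' frameworks.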